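The source may report more compounds than this note shows. Statements on the series, on what has been measured and on what is new or still open speak of the compounds shown alone.

Compound 1 `CNC(=O)[C@@H]1CCCN1S(=O)(=O)c1ccc(Cl)c(COc2cccc3c(C(F)(F)F)cc(C)nc23)c1Cl` is one of three sulfonamides built on a shared core and tested in an ADME assay on microsomes (Homo sapiens) for metabolic stability (a lower number here means slower removal, a higher number faster removal of the compound), where compound 1 gives 250 mL/min/kg. Among the three numbers this is the second highest; its nearest neighbour is compound 3 `Cc1cc(C(F)(F)F)c2cccc(OCc3c(Cl)ccc(S(=O)(=O)N4CCCCC4)c3Cl)c2n1`, which in this assay gives 233 mL/min/kg, and the furthest is compound 2 `COC[C@@H]1CCCN1S(=O)(=O)c1ccc(Cl)c(COc2cccc3c(C(F)(F)F)cc(C)nc23)c1Cl`, which in this assay gives 450 mL/min/kg. None of the three is separated from another by more than the usual scatter: the change is a 1.8-fold higher number from compound 1 to compound 2 (0.26 log units; within the scatter), a 1.1-fold lower number from compound 1 to compound 3 (0.03 log units; within the scatter) and a 1.9-fold lower number from compound 2 to compound 3 (0.29 log units; within the scatter).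

Compound 4 `Cc1cc(C(F)(F)F)c2cccc(OCc3c(Cl)ccc(S(=O)(=O)N4C[C@@H](C)O[C@@H](C)C4)c3Cl)c2n1` is the next compound to be measured. Relative to compound 1 the change is 2,6-dimethylmorpholin-4-yl in place of 2-(methylcarbamoyl)pyrrolidin-1-yl on a sulfonyl sulfur. For the measured compounds named here, the step that bears most directly on it is the one to compound 3, where a different saturated ring took the place of the 2-(methylcarbamoyl)pyrrolidin-1-yl on the sulfonyl sulfur and the result was a 1.1-fold lower number from compound 1 to compound 3 (0.03 log units; within the scatter); the exchange of the methylcarbamoyl itself, a 1.8-fold higher number from compound 1 to compound 2 (0.26 log units; within the scatter), was also within the scatter. On that basis no step beyond the scatter is expected in this assay for compound 4, whose estimated number is 260 mL/min/kg with a range from 130 mL/min/kg to 520 mL/min/kg, a step of a 1.0-fold higher number from compound 1 to compound 4 (0.02 log units; within the scatter) that is expected to stay within the scatter.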

Compound 4, clearance: 317 mL/min/kg
Beside the measured number, compound 4's estimate is 1.2-fold (0.09 log units) below it; the range from low to high includes it.
By their numbers in this assay, from the lowest: compounds 3, 1, 4 and 2 (each within the scatter of the next).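

In this assay, the sulfonyl sulfur now carries a six-membered ring with 2 hetero atoms and 2 defined stereocentres, and the read-out still stays within the scatter of every earlier compound: replacing 2-(methylcarbamoyl)pyrrolidin-1-yl gives a 1.3-fold higher number from compound 1 to compound 4 (0.10 log units; within the scatter), replacing piperidin-1-yl gives a 1.4-fold higher number from compound 3 to compound 4 (0.13 log units; within the scatter), and replacing 2-(methoxymethyl)pyrrolidin-1-yl gives a 1.4-fold lower number from compound 2 to compound 4 (0.15 log units; within the scatter). Compound 4 thus extends the earlier picture to a ring with a second hetero atom and methyl groups, so all four groups on this sulfur now fall within the scatter of one another, with no exception among the compounds shown. Nothing measured on these compounds explains this result.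

The compounds shown leave open whether any group on the sulfonyl sulfur can move this read-out beyond the scatter, for instance a piperazine ring with a free amine or a pyrrolidine carrying a carboxylic acid. They also leave open whether a change elsewhere on the shared core, such as a nitrile in place of the trifluoromethyl, would have a larger effect than any exchange at the sulfur.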